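Swapping a methyl for a methyl ester on the aryl amide

The compounds below may be only part of what the source reports. "The series", "measured", "known", "first", "only" and "open" are said of these compounds alone.

Compound 1 `Cc1cccc(NC(=O)C2(C(=O)Nc3ccc(Nc4ncc5cc(C(=O)N(C)C)n(C6CCCC6)c5n4)cc3)CC2)c1`: 86.1%
Compound 2 `Cc1ccc(NC(=O)C2(C(=O)Nc3ccc(Nc4ncc5cc(C(=O)N(C)C)n(C6CCCC6)c5n4)cc3)CC2)cc1`: 90.6%

In a functional assay on A549 cells (Homo sapiens) for inhibition, read by CCK-8 assay, with a stated time of 72 h, tested at 10 uM (a lower number here means less inhibition of growth, a higher number more inhibition of growth at the concentration tested), compound 2 gives 90.6%, within the scatter of compound 1 at 86.1%. Compound 3 `COC(=O)c1cccc(NC(=O)C2(C(=O)Nc3ccc(Nc4ncc5cc(C(=O)N(C)C)n(C6CCCC6)c5n4)cc3)CC2)c1` follows from compound 2 through one change 3-(methoxycarbonyl)phenyl in place of 4-methylphenyl on an amide-type nitrogen. Going by the values given here, the only measured step at this place, a number 4.5 percentage points higher from compound 1 to compound 2 (within the scatter), just moved the methyl group. Among the compounds with values here, no measured compound carries an ester, so that step offers only weak guidance. A slight loss, no larger than the scatter, is expected as a number 8.6 percentage points lower from compound 2 to compound 3 (within the scatter). For compound 3 the estimated value is 82%, with an expected range of 62% to 94%.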

Compound 3, percent growth inhibition at one concentration: 91%
The estimate for compound 3 lay 9 percentage points below the measured number; the range from low to high includes it.
By their numbers in this assay, from the lowest: compounds 1, 2 and 3 (each within the scatter of the next).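

The methyl ester matches both methyl compounds in this assay with a number 0.4 percentage points higher from compound 2 to compound 3 (within the scatter) and with a number 4.9 percentage points higher from compound 1 to compound 3 (within the scatter) as the two new steps. On this amide-type nitrogen, then, 3-(methoxycarbonyl)phenyl is tolerated as well as the methylphenyl groups, even though it brings hydrogen-bond acceptors that they lack. No evidence on the reason for this is available.

On these data alone, whether a carboxylic acid or an amine on this ring would also keep growth inhibition at this level remains open. All three numbers lying within the scatter also leaves open whether these compounds would separate at a lower concentration.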